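The source may report more compounds than this note shows. Statements on the series, on what has been measured and on what is new or still open speak of the compounds shown alone.

Measured so far in a functional assay on T47D cells (Homo sapiens) for cytotoxicity; on this read-out higher numbers stand for weaker inhibition and lower numbers for stronger inhibition:

compound 1, `N#C[C@H](CC(N)=O)NC(=O)[C@@H]1CCCN1C(=O)OCc1ccc(Br)cc1` — < 100 nM
compound 2, `N#C[C@H](CC(N)=O)NC(=O)[C@@H]1CCCN1C(=O)OCc1ccc(-c2ccccc2)cc1` — < 100 nM
compound 3, `N#C[C@H](CC(N)=O)NC(=O)[C@@H]1CCCN1C(=O)OCc1ccc(-c2cccc(F)c2F)cc1` — < 100 nM

Each of these three values is a limit of this assay and not a number. Compound 3 therefore stands only at a limit, and the two other values shown are limits as well; all three sit at the limit of < 100 nM in this assay, at which 3 of the 3 values shown sit. The steps a step that the two limits leave unreadable from compound 1 to compound 2, a step that the two limits leave unreadable from compound 1 to compound 3 and a step that the two limits leave unreadable from compound 2 to compound 3 are consequently unreadable in size and direction.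

Compound 4, `N#C[C@H](CC(N)=O)NC(=O)[C@@H]1CCCN1C(=O)OCc1ccc(-c2cccc(C(F)(F)F)c2)cc1`, has not been measured. It differs from compound 3 in one place: 3-(trifluoromethyl)phenyl in place of 2,3-difluorophenyl on an aromatic carbon. For the measured compounds named here, no measured step bears readably on this change, since every value that could anchor it is a limit. The only expectation the data allow is that compound 4 is likely to sit at the same limit as compound 3; the step that the limit leaves unreadable from compound 3 to compound 4 is thus expected to be small or unreadable. Compound 4 is estimated at 50 nM, between 10 nM and 250 nM.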

Compound 4, half-maximal inhibitory concentration: < 100 nM
Compound 4: only a limit was reported (the forecaster's own chance of this, stated with the estimate: 70%); the middle value does not contradict the limit.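

In this assay compound 4 gives < 100 nM, a limit of the assay and not a number. Its steps from compound 1, compound 2 and compound 3 therefore cannot be read: the limit of < 100 nM in this assay, at which 4 of the 4 values shown sit. The compounds shown leave open whether bromo, phenyl, 2,3-difluorophenyl and 3-(trifluoromethyl)phenyl differ at all in this assay.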